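A few compounds are considered here, and "the series" means these few. Any claim that something is new, unique, unknown or untested is made for them only; others in the source may bear on it.

Working notes on the series. Within the data shown here, compound 2 `Cc1cc(Sc2ccncc2)c(S(C)(=O)=O)cc1C(=O)N=C(N)N` is the benchmark here: in a functional assay for inhibition of sodium/hydrogen exchanger (Oryctolagus cuniculus) (a higher number here means a weaker inhibitor, a lower number a stronger inhibitor), compound 2 gives 13 nM, the lowest of the two numbers measured so far. Among the measured compounds shown here, its nearest neighbour is compound 1 `Cc1cc(-c2ccc(Cl)cc2Cl)c(S(C)(=O)=O)cc1C(=O)N=C(N)N`, which in this assay gives 42 nM; the single step recorded, a 3.2-fold lower number from compound 1 to compound 2 (0.51 log units; beyond the scatter), came with (pyridin-4-yl)sulfanyl in place of 2,4-dichlorophenyl on an aromatic carbon.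

Compound 3 `Cc1cc(OC(C)(C)C)c(S(C)(=O)=O)cc1C(=O)N=C(N)N` is not yet measured. The change from compound 2 is tert-butoxy in place of (pyridin-4-yl)sulfanyl on an aromatic carbon. For the measured compounds named here, the one measured step does not cover this exchange: it swapped one ring-bearing group for another, whereas here a ring-bearing group gives way to tert-butoxy, which has no ring. What the two measured values show is that a group with a six-membered aromatic ring at this carbon is tolerated in both forms, with the substituted variant landing between them and below. Without a closer precedent, a step of about the same size as the one recorded, in the weaker direction, is expected: a 2.3-fold higher number from compound 2 to compound 3 (0.36 log units; beyond the scatter). Compound 3 is estimated at 30 nM, within 8 nM to 120 nM.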

Compound 3, half-maximal inhibitory concentration: 9.4 nM
For compound 3 the middle estimate is 3.2-fold (0.50 log units) above the measured one; low and high end bracket the measured number.
By their numbers in this assay, from the lowest: compounds 3 and 2 (each within the scatter of the next); then compound 1.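

With a 1.4-fold lower number from compound 2 to compound 3 (0.14 log units; within the scatter), tert-butoxy and (pyridin-4-yl)sulfanyl cannot be told apart in this assay at this aromatic carbon, ortho to a methylsulfonyl group, so a six-membered aromatic ring in the substituent is not required for a number at this level. The change from 2,4-dichlorophenyl to the ring-free group gives a 4.5-fold lower number from compound 1 to compound 3 (0.65 log units; beyond the scatter), so among the three groups shown 2,4-dichlorophenyl stands apart, with the steps from compound 1 to both other compounds lying beyond the scatter. No measurement is at hand that would explain these numbers.

The compounds shown leave open whether this result is particular to tert-butoxy or also holds for methoxy, an amine or a carboxylic acid on the same carbon. They also cannot separate the part played by the ether oxygen of tert-butoxy from that of its carbons, a question that a neopentyl group at this position would address.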